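A few compounds are considered here, and "the series" means these few. Any claim that something is new, unique, unknown or untested is made for them only; others in the source may bear on it.

Working notes on the series. Compound 1, `COc1nc(-c2ccsc2)ccc1[C@@H](c1ccccc1)[C@@](O)(CCN(C)C)c1cccc2ccccc12`, sits at a limit in a toxicity assay on HeLa cells (Homo sapiens) for cytotoxicity; a lower number here means that less compound is tolerated, a higher number that more compound is tolerated: it gives > 64 ug/mL, which is a limit of the assay and not a number. Among the compounds with values here, compound 2, `COc1nc(-c2cccc(F)c2)ccc1[C@@H](c1ccccc1)[C@@](O)(CCN(C)C)c1cccc2ccccc12`, gives 62.8 ug/mL in this assay, the only number among the values shown. Within the data shown here, the one measured step, an at least 1.0-fold lower number from compound 1 to compound 2 (0.00 log units; that floor lies within the scatter), stays within the scatter, and the limit of > 64 ug/mL in this assay, at which 1 of the 2 values shown sits, is the only evidence on it.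

Compound 3, `COc1nc(-c2cnsc2)ccc1[C@@H](c1ccccc1)[C@@](O)(CCN(C)C)c1cccc2ccccc12`, is not yet measured. It differs from compound 2 by 1,2-thiazol-4-yl in place of 3-fluorophenyl on an aromatic carbon. The step from compound 1 to compound 2 also exchanged the ring on that aromatic carbon, a thiophen-3-yl for a 3-fluorophenyl, and moved the number by no more than the scatter. The change to compound 3 brings back a five-membered ring with hetero atoms on the same carbon, so no step beyond the scatter is expected in this assay, and the result may again come out as a limit rather than a number. The estimated step is a 1.0-fold higher number from compound 2 to compound 3 (0.01 log units; within the scatter). For compound 3 the expected value is 64 ug/mL, within a range of 35 ug/mL to 130 ug/mL.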

Compound 3, half-maximal cytotoxic concentration: 28.8 ug/mL
Beside the measured number, compound 3's estimate is 2.2-fold (0.35 log units) above it, and the stated range ends above it.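

In this assay, the ring on this aromatic carbon next to the ring nitrogen can move the number beyond the scatter after all, with a 2.2-fold lower number from compound 2 to compound 3 (0.34 log units; beyond the scatter), whereas the earlier exchange at this carbon did not. Five-membered rings on this carbon also do not behave alike, since 1,2-thiazol-4-yl in place of thiophen-3-yl gives an at least 2.2-fold lower number from compound 1 to compound 3 (0.34 log units; beyond the scatter), so ring size alone does not set the tolerated concentration. Compound 1 stands at a limit of the assay and not at a number, which makes that step a floor whose true size stays unknown: the limit of > 64 ug/mL in this assay, at which 1 of the 3 values shown sits.

Compound 3 is the only compound here with 1,2-thiazol-4-yl, so the compounds shown do not tell whether the lower number goes with the ring nitrogen, with the arrangement of the hetero atoms, or with this ring alone. On these data alone, whether a pyridin-3-yl or an isoxazol-4-yl ring on the same carbon would fall nearer compound 3 or nearer compound 2 also stays open.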